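A few compounds are considered here, and "the series" means these few. Any claim that something is new, unique, unknown or untested is made for them only; others in the source may bear on it.

Among the measured compounds shown here, in a toxicity assay on Vero cells (Chlorocebus sabaeus) for cytotoxicity, read by colorimetric assay and MTT assay, with a stated time of 72 h (on this read-out lower numbers stand for higher toxicity in this test and higher numbers for lower toxicity in this test), compound 1 `Nc1cccc(F)c1C(=O)NNc1ccc(Cl)cc1` gives 373000 nM, while compound 2 `Nc1cccc(F)c1C(=O)NNc1ccc(Cl)cc1Cl` gives 1040000 nM, the higher of the two numbers so far. Compound 3 `Nc1cccc(F)c1C(=O)NNc1c(Cl)cc(Cl)cc1Cl` differs from compound 2 at one place: chloro in place of hydrogen on an aromatic carbon. For the measured compounds named here, only one measured step bears on this, the same replacement of hydrogen by chloro on an aromatic carbon, and it was modest: a 2.8-fold higher number from compound 1 to compound 2 (0.45 log units; beyond the scatter). With a single precedent, another modest move toward a higher number is expected in this assay. The estimate amounts to an expected 1.5-fold higher number from compound 2 to compound 3 (0.19 log units; within the scatter). For compound 3 the estimated value is 1600000 nM, with an expected range from 500000 nM to 4500000 nM.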

Compound 3, half-maximal cytotoxic concentration: > 1800000 nM
Compound 3 gave a limit, no number; the forecaster's own chance of this, stated with the estimate: 20%; at least 1.1-fold (0.05 log units) between middle value and limit.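

Chloro in place of hydrogen on an aromatic carbon, here ortho to a large group and meta to two chloro groups, gives an at least 1.7-fold higher number from compound 2 to compound 3 (0.23 log units; that floor lies within the scatter). This step does not reverse the direction seen earlier in this assay, although its floor alone does not establish a further rise. Compound 3 gave a limit and not a number: the limit of > 1800000 nM in this assay, at which 1 of the 3 values shown sits.

On these data alone, what a methyl or a methoxy group would do at this position stays open, and so does the actual size of this step.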